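Adding a Methyl to a Propargyl Amide Chain

A few compounds are considered here, and "the series" means these few. Any claim that something is new, unique, unknown or untested is made for them only; others in the source may bear on it.

Compound 2, with structure `CC(=O)N(C)CC#CCn1cncc1C`, and compound 1, with structure `CC(=O)N(C)C(C)C#CCn1cncc1C`, share a core and differ in one spot: methyl in place of hydrogen on a saturated chain carbon bound to an amide-type nitrogen and a triple-bonded carbon. In a functional assay on the whole organism for agonist activity, with Mus musculus as the target (on this read-out higher numbers stand for an effect only at larger amounts of compound and lower numbers for an effect already at smaller amounts), compound 2 gives 45 mg/kg. Compound 1 reaches only the limit of the assay, > 100 mg/kg, which is not a number. The step of an at least 2.2-fold higher number from compound 2 to compound 1 (0.34 log units; beyond the scatter) therefore shows that the methyl made the effect appear only at larger amounts.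

Compound 3, with structure `CCOC(=O)N(C)CC#CCN1CCCC1`, has a different core; the difference between the two cores is not broken down here. In this assay compound 3 also sits at the limit, > 100 mg/kg, so no number is known for it. Compound 4, with structure `CCOC(=O)N(C)C(C)C#CCN1CCCC1`, is not yet measured. It is built from compound 3 by the same change seen before: methyl in place of hydrogen on a saturated chain carbon bound to an amide-type nitrogen and a triple-bonded carbon. The change is the same in both pairs, since the methyl enters at the same kind of place.

The step expected from compound 3 to compound 4 is a step that the limit leaves unreadable from compound 3 to compound 4, which rests on the step of an at least 2.2-fold higher number from compound 2 to compound 1 (0.34 log units; beyond the scatter) and on the fact that (the limit of > 100 mg/kg in this assay, at which 2 of the 3 values shown sit). Compound 4 is thus expected to give about 300 mg/kg in this assay, most likely again only as a limit, within a range from 100 mg/kg to 1500 mg/kg.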

Compound 4, dose for half-maximal effect: > 100 mg/kg
Compound 4 was reported as a limit (the forecaster's own chance of this, stated with the estimate: 90%); the middle value does not contradict the limit.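

In this assay, no step can be read from compound 3 to compound 4, because both results are limits of the assay and not numbers: the limit of > 100 mg/kg in this assay, at which 3 of the 4 values shown sit.

The compounds shown leave open what dose compound 3 and compound 4 actually need for their effect, and whether the added methyl shifts that dose on their core as it did on the core of compound 2.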